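What Happens When Compound 1 Loses Its Methoxy?

The compounds below may be only part of what the source reports. "The series", "measured", "known", "first", "only" and "open" are said of these compounds alone.

Compound 1 `COc1ccc(N2C(=O)COc3ccc(-c4cnc(Cl)c(NS(=O)(=O)c5ccc(F)cc5)c4)cc32)cc1` was tested in a functional assay on HepG2 cells (Homo sapiens) for antiproliferative activity, read by MTT assay, with a stated time of 72 h; on this read-out higher numbers stand for weaker inhibition and lower numbers for stronger inhibition. There, compound 1 gives > 40000 nM, which is a limit of the assay and not a number. Compound 3 `Cc1ccc(N2C(=O)COc3ccc(-c4cnc5ccccc5c4)cc32)cc1` gives > 40000 nM, which is also a limit. Only compound 2 `COc1cccc(N2C(=O)COc3ccc(-c4ccc(O)cc4)cc32)c1` returns a true number, 26100 nM. Compound 1 therefore stands at the limit of > 40000 nM in this assay, at which 2 of the 3 values shown sit.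

Compound 4 `O=C1COc2ccc(-c3cnc(Cl)c(NS(=O)(=O)c4ccc(F)cc4)c3)cc2N1c1ccccc1` has hydrogen in place of methoxy on an aromatic carbon, para to a large group, so 4-methoxyphenyl becomes phenyl: hydrogen in place of methoxy on an aromatic carbon. Among the measured compounds shown here, no pair of measured compounds shows this change on its own. In this assay I therefore expect no step beyond the usual scatter, and no clear direction. The estimated step is a number no higher from compound 1 to compound 4 (the limit leaves the size open). With compound 1 at its limit of > 40000 nM, another limit is the most likely report for the new compound. For compound 4 the estimated value is 40000 nM, with an expected range from 15000 nM to 80000 nM.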

Compound 4, half-maximal inhibitory concentration: 35700 nM
Estimate against measurement, compound 4: 1.1-fold (0.05 log units) above; the measured number falls inside the stated range.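

Of the two compounds that differ only at this place, compound 4 is the one that returns a true number in this assay, so the phenyl compound gives a measured value where the 4-methoxyphenyl compound does not. Compound 1 gives > 40000 nM, which is a limit of the assay and not a number. Going by these compounds, replacing methoxy with hydrogen therefore gives an at least 1.1-fold lower number from compound 1 to compound 4 (0.04 log units; that floor lies within the scatter), and the true size of this step stays open.

On these data alone, it also remains open whether an amine or a carboxylic acid at this place, para to a large group, would move the number further. Another open question is how the same change reads on a compound whose methoxy form returns a true number, where the full step could be seen.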